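The compounds below may be only part of what the source reports. "The series", "measured", "known", "first", "only" and "open" are said of these compounds alone.

In a functional assay on HepG2 cells (Homo sapiens) for antiproliferative activity, read by MTT assay, with a stated time of 48 h (on this read-out lower numbers stand for stronger inhibition and higher numbers for weaker inhibition), three compounds sharing one core have been measured. Compound 1 `Brc1ccc(CNc2ccc3ncnc(Nc4cccc(Br)c4)c3c2)cc1` gives 1410 nM, compound 2 `Clc1ccccc1CNc1ccc2ncnc(Nc3cccc(Br)c3)c2c1` gives 1820 nM, and compound 3 `COc1ccc(CNc2ccc3ncnc(Nc4cccc(Br)c4)c3c2)cc1` gives 5430 nM. Compound 2 cannot be told apart from compound 1, with a 1.3-fold higher number from compound 1 to compound 2 (0.11 log units; within the scatter), while compound 3 stands clear of both, with a 3.0-fold higher number from compound 2 to compound 3 (0.47 log units; beyond the scatter) and a 3.9-fold higher number from compound 1 to compound 3 (0.59 log units; beyond the scatter).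

Compound 4 `Clc1cccc(Nc2ncnc3ccc(NCc4ccccc4Cl)cc23)c1` departs from compound 2 at one place: chloro in place of bromo on an aromatic carbon, meta to a large group. Going by the values given here, no measured step touches this group, so the evidence is indirect. The closest parallel is the swap of 4-bromophenyl for 2-chlorophenyl elsewhere on the molecule, which stayed within the scatter in a 1.3-fold higher number from compound 1 to compound 2 (0.11 log units; within the scatter). The larger 3.9-fold higher number from compound 1 to compound 3 (0.59 log units; beyond the scatter) came from methoxy replacing bromo, a different kind of exchange. No step beyond the scatter is therefore expected in this assay. The expected change is a 1.0-fold higher number from compound 2 to compound 4 (0.02 log units; within the scatter). For compound 4, the estimated value is 1900 nM, with an expected range from 900 nM to 4000 nM.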

Compound 4, half-maximal inhibitory concentration: 5330 nM
For compound 4 the middle estimate is 2.8-fold (0.45 log units) below the measured one; measured number above the stated range.
By their numbers in this assay, from the lowest: compounds 1 and 2 (each within the scatter of the next); then compounds 4 and 3 (each within the scatter of the next).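

In this assay, the exchange of 3-bromophenyl for 3-chlorophenyl on the amino group is not a silent one, with a 2.9-fold higher number from compound 2 to compound 4 (0.47 log units; beyond the scatter). Going by these compounds alone, this is the first reading at this position, on an aromatic carbon meta to a large group, and it shows that replacing bromo with chloro here moves the number beyond the scatter, whereas the change on the other side of the molecule, a 1.3-fold higher number from compound 1 to compound 2 (0.11 log units; within the scatter), did not. Nothing available explains why this exchange has such an effect at this position.

As far as these compounds go, it remains open whether bromo to chloro gives a step of this size when 4-bromophenyl or 4-methoxyphenyl replaces the 2-chlorophenyl group. From the compounds shown here alone, how a fluoro, methyl or nitrile group would read at this position also remains open.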